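The source may report more compounds than this note shows. Statements on the series, on what has been measured and on what is new or still open speak of the compounds shown alone.

For the measured compounds named here, compound 2 `C=CC1=C(C(=O)NCc2ccccc2)C(c2ccc(OC)cc2)OC1` is one of three compounds measured in a functional assay on QGY7701 cells (Homo sapiens) for cytotoxicity, read by MTT assay, with a stated time of 24 h; a higher number here means a weaker inhibitor, a lower number a stronger inhibitor. In this assay compound 2 gives only a limit, > 100000 nM. Compound 1 `C=CC1=C(C(=O)NCc2ccccc2)C(c2ccc(OC)c(OC)c2)OC1` likewise gives a limit in this assay, > 100000 nM. Compound 3 `C=CC1=C(C(=O)NCCCCC)C(c2ccc(F)cc2)OC1` also gives a limit in this assay, > 100000 nM. Going by the values given here, the one step among them that differs in a single place, a step that the two limits leave unreadable from compound 1 to compound 2, cannot be read because of the limit of > 100000 nM in this assay, at which 3 of the 3 values shown sit. Compound 2 therefore stands at the limit of this assay, with no number to place it more precisely.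

Compound 4 `C=CC1=C(C(=O)NCc2ccccc2F)C(c2ccc(OC)cc2)OC1` has not yet been measured in this assay. Its difference from compound 2 is fluoro in place of hydrogen on an aromatic carbon. No measured step bears directly on this change: the only step shown concerns a methoxy group, and its size is not readable. With all values shown sitting at the limit, there is no basis for expecting a step in either direction beyond the scatter, and the account expects compound 4 to remain where compound 2 stands. The estimated step from compound 2 to compound 4 is a step that the limit leaves unreadable from compound 2 to compound 4. Compound 4 is expected to give about 150000 nM, between 60000 nM and 400000 nM, in this assay.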

Compound 4, half-maximal inhibitory concentration: > 100000 nM
Compound 4: a limit, no number (the forecaster's own chance of this, stated with the estimate: 85%); the middle value is on the limit's open side.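

No step can be read from compound 2 to compound 4, because both compounds give only a limit: the limit of > 100000 nM in this assay, at which 4 of the 4 values shown sit.

The compounds shown leave open where any of them would give an actual number in this assay, and so whether fluoro in place of hydrogen on the benzyl ring changes the read-out at all.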